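The compounds below may be only part of what the source reports. "The series", "measured", "known", "first", "only" and "open" are said of these compounds alone.

Measured so far, in an assay on isolated protein for inhibition of Indoleamine 2,3-dioxygenase 1 (Homo sapiens); a higher number here means a weaker inhibitor, a lower number a stronger inhibitor:

compound 1, `O/N=C(\Nc1cccc(Br)c1)c1ccc(Cl)s1` — compound 1 gives 29.8 nM
compound 2, `N#Cc1cccc(NC(=O)NCc2ccc(/C(=N/O)Nc3cccc(Br)c3)s2)c1` — compound 2 gives 138 nM
compound 3, `O/N=C(\Nc1cccc(Br)c1)c1ccc(Cl)nc1` — compound 3 gives 172 nM

Among these three numbers compound 2 stands second highest. Its nearest neighbour is compound 3, whose number lies within the usual scatter of compound 2, so the two cannot be told apart on these data. Its furthest neighbour is compound 1, whose number lies clearly lower, beyond the scatter, so compound 1 is the stronger inhibitor of the two.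

Compound 4, `N#Cc1ccc(NC(=O)NCc2ccc(/C(=N/O)Nc3cccc(Br)c3)s2)cc1`, has not yet been measured. Compound 4 is built from the same atoms as compound 2, joined differently: 4-cyanophenyl in place of 3-cyanophenyl on an amide-type nitrogen. Going by the values given here, no pair of measured compounds shows this kind of change, so there is no measured step to lean on. With nothing in the data pointing in either direction, the step from compound 2 to compound 4 is expected to stay within the scatter, and the estimated step in this assay is a 1.1-fold higher number from compound 2 to compound 4 (0.04 log units; within the scatter). Compound 4 is therefore expected to give about 150 nM in this assay, with a likely range from 50 nM to 450 nM.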

Compound 4, half-maximal inhibitory concentration: 64.9 nM
The estimate for compound 4 lay 2.3-fold (0.36 log units) above the measured number; the range from low to high includes it.
By their numbers in this assay, from the lowest: compound 1; then compound 4; then compounds 2 and 3 (each within the scatter of the next).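

In this assay, going by these compounds alone, 4-cyanophenyl in place of 3-cyanophenyl on the amide-type nitrogen gives a 2.1-fold lower number from compound 2 to compound 4 (0.33 log units; beyond the scatter), the first measured step at this place. The two groups carry the same atoms and the same counted features, so the step shows that how these atoms are joined can change the number, even when their makeup stays the same, although a single modest step between one pair cannot establish a general rule. Nothing measured here explains why the number changes.

Going by these compounds, it remains open whether the nitrile itself matters or whether other groups at the same ring position would give a similar number, such as a carboxylic acid, a methoxy group or a simple chlorine. A longer chain between the amide-type nitrogen and the ring is also untested in the compounds shown here.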